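The compounds below may be only part of what the source reports. "The series", "measured", "known", "first", "only" and "open" are said of these compounds alone.

In a functional assay on AGS cells (Homo sapiens) for inhibition, read by reporter gene assay (on this read-out higher numbers stand for weaker inhibition and lower numbers for stronger inhibition), compound 1 `CC(=O)c1ccc(OCC(=O)Nc2cccc(C(=O)O)c2)cc1`, with acetyl, reads > 30000 nM, which is a limit of the assay. Compound 2 `O=C(COc1ccc(F)cc1)Nc1cccc(C(=O)O)c1`, with fluoro, reads > 30000 nM, again a limit. Going by the values given here, compound 3 `O=C(COc1ccc(Br)cc1)Nc1cccc(C(=O)O)c1`, with bromo, gives 1600 nM, the only actual number in the set. Compound 4 `O=C(COc1ccc(-c2cccs2)cc1)Nc1cccc(C(=O)O)c1` has thiophen-2-yl in place of bromo on an aromatic carbon. The measured steps at this carbon are an at least 18-fold lower number from compound 1 to compound 3 (1.27 log units; beyond the scatter) and an at least 18-fold lower number from compound 2 to compound 3 (1.27 log units; beyond the scatter), both large, so the group there matters. Neither step brings in a ring, so they give no clear direction for this change. The expected change is a 1.6-fold lower number from compound 3 to compound 4 (0.20 log units; within the scatter), with no step beyond the scatter anticipated. For compound 4 the estimate is 1000 nM, with an expected range of 200 nM to 7000 nM.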

Compound 4, half-maximal inhibitory concentration: > 30000 nM
Compound 4 ended at the assay's limit; the forecaster's own chance of this, stated with the estimate: 15%; at least 30-fold (1.47 log units) between middle value and limit.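

Thiophen-2-yl in place of bromo gives an at least 18-fold higher number from compound 3 to compound 4 (1.27 log units; beyond the scatter), so on this aromatic carbon, para to a large group, a five-membered aromatic ring does not keep the inhibition seen with bromo. Bromo remains the only group here that gives a number, and compound 4 reads at a limit, as do compound 1 and compound 2: the limit of > 30000 nM in this assay, at which 3 of the 4 values shown sit. The steps from compound 1 and from compound 2 to compound 4 cannot be read. On these data alone, whether chloro or iodo would also give a number at this carbon stays open. So does whether phenyl or a methyl-bearing thiophene would behave as thiophen-2-yl does.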